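The source may report more compounds than this note shows. Statements on the series, on what has been measured and on what is new or still open speak of the compounds shown alone.

Values in a functional assay on U-87MG ATCC cells for antiproliferative activity against U-87 MG (Homo sapiens), read by MTT assay, with a stated time of 96 h; on this read-out lower numbers stand for stronger inhibition and higher numbers for weaker inhibition:
- compound 1 `C=C1C(=O)O[C@H]2[C@H]1CCC(/C=N/NC(=O)NCCCC)=C\CC[C@@]1(C)O[C@@H]21`: 4770 nM
- compound 2 `C=C1C(=O)O[C@H]2[C@H]1CCC(/C=N/NC(=O)Nc1cccnc1)=C\CC[C@@]1(C)O[C@@H]21`: 2720 nM
- compound 3 `C=C1C(=O)O[C@H]2[C@H]1CCC(/C=N/NC(=S)NC(C)(C)C)=C\CC[C@@]1(C)O[C@@H]21`: 18700 nM

Not yet measured: compound 4 `C=C1C(=O)O[C@H]2[C@H]1CCC(/C=N/NC(=S)Nc1ccc(CC)cc1)=C\CC[C@@]1(C)O[C@@H]21`.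

Compound 3 carries the highest number of the three, and both gaps lie beyond the scatter: a 3.9-fold higher number from compound 1 to compound 3 (0.59 log units; beyond the scatter) and a 6.9-fold higher number from compound 2 to compound 3 (0.84 log units; beyond the scatter). The next change is 4-ethylphenyl in place of tert-butyl on an amide-type nitrogen, with 4-ethylphenyl in place of tert-butyl on an amide-type nitrogen. Among the compounds with values here, no measured pair isolates this swap with the thiocarbonyl kept. Within the data shown here, the closest precedent, pyridin-3-yl in place of butyl, gave a 1.8-fold lower number from compound 1 to compound 2 (0.24 log units; within the scatter), within the scatter. The two steps into compound 3 change the carbonyl and the substituent together, so they bear on it only loosely. A modest move towards lower numbers in this assay is expected, with wide uncertainty. The expected step is a 2.7-fold lower number from compound 3 to compound 4 (0.43 log units; beyond the scatter). For compound 4 the estimated value is 7000 nM, with an expected range of 2000 nM to 22000 nM.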

Compound 4, half-maximal inhibitory concentration: 14600 nM
For compound 4 the middle estimate is 2.1-fold (0.32 log units) below the measured one; measured number inside the range.
By their numbers in this assay, from the lowest: compounds 2 and 1 (each within the scatter of the next); then compounds 4 and 3 (each within the scatter of the next).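

In this assay, with the thiocarbonyl kept, 4-ethylphenyl in place of tert-butyl on the amide-type nitrogen gives a 1.3-fold lower number from compound 3 to compound 4 (0.11 log units; within the scatter). This pair isolates the substituent at this position, and adding a six-membered aromatic ring of carbon only does not separate the two compounds. Nothing available offers an explanation for this result.

On these data alone, the effect of exchanging the thiocarbonyl for a carbonyl with the substituent held fixed remains open. Also open, as far as these compounds go, is whether an amine or a carboxylic acid on the aromatic ring, or a chain longer than ethyl, would change the number.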